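Series notes: from compound 3 to compound 4

A few compounds are considered here, and "the series" means these few. Any claim that something is new, unique, unknown or untested is made for them only; others in the source may bear on it.

Compound 3 `COc1ccc(/C=C/C(=O)c2c(O)cc(O)cc2OC)cc1` gives 166000 nM in a toxicity assay on cells (Macrophage, Mus musculus, strain BALB/c) for cytotoxicity, read by MTT assay (on this read-out lower numbers stand for stronger inhibition and higher numbers for weaker inhibition), the second highest of the three numbers; compound 1 `COc1cc(O)cc(O)c1C(=O)/C=C/c1ccc(F)cc1` gives 28800 nM and compound 2 `COc1cc(O)cc(O)c1C(=O)/C=C/c1ccco1` gives 384000 nM. The measured steps are a 5.8-fold higher number from compound 1 to compound 3 (0.76 log units; beyond the scatter) and a 13-fold higher number from compound 1 to compound 2 (1.12 log units; beyond the scatter). Compound 4 `COc1cc(O)cc(O)c1C(=O)/C=C/c1ccc(O)cc1` differs from compound 3 by hydrogen in place of methyl on an oxygen on an aromatic ring. Among the measured compounds shown here, no measured step removes a methyl from an oxygen; the step of a 5.8-fold higher number from compound 1 to compound 3 (0.76 log units; beyond the scatter) exchanged a different group at an aromatic carbon, so it bears only loosely, and the furan exchange does not bear at all. Removing the methyl is therefore expected to give at most a modest step, a 1.2-fold lower number from compound 3 to compound 4 (0.07 log units; within the scatter), with no firm direction. Compound 4 is estimated at 140000 nM, between 55000 nM and 380000 nM.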

Compound 4, half-maximal inhibitory concentration: 21700 nM
The estimate for compound 4 lay 6.5-fold (0.81 log units) above the measured number; measured number below the stated range.
By their numbers in this assay, from the lowest: compounds 4 and 1 (each within the scatter of the next); then compound 3; then compound 2.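

In this assay, the methyl on this oxygen turns out to count: methoxy to hydroxy gives a step well outside the scatter (a 7.6-fold lower number from compound 3 to compound 4 (0.88 log units; beyond the scatter)). Hydroxy and fluoro on this aromatic carbon cannot be told apart (a 1.3-fold lower number from compound 1 to compound 4 (0.12 log units; within the scatter)), so methoxy alone stands off among the three groups, while 4-hydroxyphenyl in place of furan-2-yl gives a large step (an 18-fold lower number from compound 2 to compound 4 (1.25 log units; beyond the scatter)). Nothing available accounts for the methoxy result.

Going by these compounds, whether an ethoxy, a chlorine or an amine on this carbon would group with methoxy or with hydroxy and fluoro stays open. Also open, on these data alone, is whether removing the methyl from the methoxy on the shared core would give a step of similar size.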